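Chloro in place of hydrogen: an expected outcome

This account rests on a few compounds, and the source may have more. Where it says the series, first, only, none or still open, it means among the compounds named here.

Compound 1 `Fc1ccccc1-c1noc(Cn2cncn2)n1`: < 50 mg/kg
Compound 2 `c1ccc(-c2noc(Cn3cncn3)n2)cc1`: 37 mg/kg

Among the measured compounds shown here, in a functional assay on the whole organism (strain Wistar) with Rattus norvegicus as the target, with a stated time of 2 h (on this read-out higher numbers stand for an effect only at larger amounts of compound and lower numbers for an effect already at smaller amounts), compound 2 gives 37 mg/kg, the only number recorded so far. For compound 1 the result < 50 mg/kg is a limit of the assay, not a number (the limit of < 50 mg/kg in this assay, at which 1 of the 2 values shown sits). For the measured compounds named here, the single measured step, a step that the limit leaves unreadable from compound 1 to compound 2, therefore cannot be read in size. Compound 3 `Clc1ccc(-c2noc(Cn3cncn3)n2)cc1` differs from compound 2 by chloro in place of hydrogen on an aromatic carbon. No readable step bears on this change, so the expected step is a 1.2-fold lower number from compound 2 to compound 3 (0.09 log units; within the scatter), within the scatter. Compound 3 is accordingly estimated at 30 mg/kg, ranging from 12 mg/kg to 75 mg/kg.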

Compound 3, dose for half-maximal effect: 29.5 mg/kg
The estimate for compound 3 lay 1.0-fold (0.01 log units) above the measured number, within the range that was stated.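

Among the compounds shown here, with chloro on an aromatic carbon para to a large group, this assay gives the first readable step, a 1.3-fold lower number from compound 2 to compound 3 (0.10 log units; within the scatter), whereas the step from compound 1 to compound 2 cannot be read. This position therefore takes a chloro with no difference that stands out from the scatter. The data shown offer no cause for this result. Going by these compounds, what an amine or a carboxylic acid at the same position would do remains open, as does whether any group there moves the dose beyond the scatter.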